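A few compounds are considered here, and "the series" means these few. Any claim that something is new, unique, unknown or untested is made for them only; others in the source may bear on it.

For the measured compounds named here, compound 1, `Cc1ccc2nc(C(=O)Nc3c(F)cc(-c4cccc(F)c4)cc3F)c(C)c(O)c2c1`, is one of two compounds measured in a functional assay on A-375 cells (Homo sapiens) for antiproliferative activity, read by MTT assay, with a stated time of 24 h, tested at 0.14 ug/mL (a higher number here means a stronger effect of the compound at the concentration tested, a lower number a weaker effect), where compound 1 gives 1.06%. The other, compound 2, `Cc1c(C(=O)Nc2c(F)cc(-c3cccc(F)c3)cc2F)nc2ccc(F)cc2c1O`, gives 0% in this assay. The two read-outs lie within the usual scatter of each other, the step between them being a number 1.1 percentage points lower from compound 1 to compound 2 (within the scatter). Nothing measured here therefore separates compound 1 from compound 2, and both read-outs are small at the concentration tested.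

Compound 3, `Cc1c(C(=O)Nc2c(F)cc(-c3cccc(F)c3)cc2F)nc2ccc(C(F)(F)F)cc2c1O`, is not yet measured in this assay. Its difference from compound 1 is trifluoromethyl in place of methyl on an aromatic carbon. Going by the values given here, the only measured step that bears on it is the one from compound 1 to compound 2, which replaced the same methyl on the same aromatic carbon and was a number 1.1 percentage points lower from compound 1 to compound 2 (within the scatter). Because that earlier step was a number 1.1 percentage points lower from compound 1 to compound 2 (within the scatter), compound 3 is expected to move from compound 1 by a number 0.9 percentage points higher from compound 1 to compound 3 (within the scatter), a step not beyond the scatter. The estimate for compound 3 in this assay is 2%, with a range from 0% to 12%.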

Compound 3, a percentage reported as inhibition, at one concentration (the size of the read-out at that concentration, not a potency): 9.37%
Beside the measured number, compound 3's estimate is 7.4 percentage points below it; low and high end bracket the measured number.
By their numbers in this assay, from the lowest: compounds 2, 1 and 3 (each within the scatter of the next).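

On this aromatic carbon, trifluoromethyl in place of methyl gives a number 8.3 percentage points higher from compound 1 to compound 3 (within the scatter) in this assay and trifluoromethyl in place of fluoro gives a number 9.4 percentage points higher from compound 2 to compound 3 (within the scatter) on the same carbon. For the compounds shown here, the earlier pair compared only two groups of one heavy atom each, whereas here a group of four heavy atoms enters, and still no step at this position lies beyond the scatter, so methyl, fluoro and trifluoromethyl cannot be told apart by this read-out. No available measurement bears on why this position tolerates these three groups alike.

The compounds shown leave open whether a group of a different kind on this carbon, such as an amine, a carboxylic acid or a longer alkyl chain, would give a step beyond the scatter, or whether the read-out stays as flat as it does for these three. They also leave open how these compounds compare in potency, since a read-out at one concentration is not a potency, and whether changes elsewhere on the shared core would separate them.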